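Aryl urea for benzyl on the ring amine nitrogen

The source may hold more compounds than are shown below. What is called first, only, known or untested is meant among the compounds shown, and "the series" means these compounds.

Compound 1 `NC(=O)c1c(NC(=O)c2ccccc2F)sc2c1CCN(Cc1cccc(Cl)c1)C2` gives 19800 nM in a functional assay on HL-60 cells (Homo sapiens) for antiproliferative activity, with a stated time of 24 h (on this read-out higher numbers stand for weaker inhibition and lower numbers for stronger inhibition), the highest of the two numbers in hand, though the gap to compound 2 is within the scatter. Compound 2 `CSc1ccccc1NC(=S)N1CCc2c(sc(NC(=O)c3ccccc3Cl)c2C(N)=O)C1` gives 14600 nM in this assay. Compound 3 `NC(=O)c1c(NC(=O)c2ccccc2F)sc2c1CCN(C(=O)Nc1ccccc1Cl)C2` is not yet measured and differs from compound 1 in one place: (2-chlorophenyl)carbamoyl in place of 3-chlorobenzyl on an amine nitrogen in a ring. Because compound 2, which also carries an aryl-bearing group on that ring nitrogen, gives 14600 nM, the step of a 1.7-fold lower number from compound 1 to compound 3 (0.22 log units; within the scatter) is expected to be small, if anything toward stronger inhibition. The estimate for compound 3 in this assay is 12000 nM, between 4000 nM and 40000 nM.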

Compound 3, half-maximal inhibitory concentration: 32700 nM
For compound 3 the middle estimate is 2.7-fold (0.44 log units) below the measured one; low and high end bracket the measured number.
By their numbers in this assay, from the lowest: compounds 2, 1 and 3 (each within the scatter of the next, the first and the last beyond it).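

On an amine nitrogen in a ring, (2-chlorophenyl)carbamoyl in place of 3-chlorobenzyl gives a 1.7-fold higher number from compound 1 to compound 3 (0.22 log units; within the scatter) in this assay, so this exchange does not separate the two compounds on this read-out. Among the compounds shown here, the entering group brings a hydrogen-bond donor and a hydrogen-bond acceptor, and the chlorine also stands at a different numbered position, so the single step cannot divide these changes. No measured evidence bears on this result.

From the compounds shown here alone, a plain benzyl, an acetyl group or the free ring amine at this nitrogen remains open. So does whether any group here moves this read-out beyond the scatter.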